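The source may hold more compounds than are shown below. What is called first, only, known or untested is meant among the compounds shown, and "the series" means these compounds.

Measured so far in an assay on cells with melanin-concentrating hormone receptor 1 (Homo sapiens) as the target, read by radioligand binding; on this read-out higher numbers stand for weaker inhibition and lower numbers for stronger inhibition:
compound 1, `Nc1ccc2cccc(OCCC3CCCCC3)c2n1`: 808 nM
compound 2, `CCCC(C)Oc1cccc2ccc(N)nc12`: 105 nM
compound 3, `CCOCCOc1cccc2ccc(N)nc12`: > 2000 nM, which is a limit of this assay and not a number the limit of > 2000 nM in this assay, at which 1 of the 3 values shown sits.

Compound 3 thus stands at the weak end of the three, known only by that limit. The next step takes (2-methylprop-1-en-1-yl in place of ethoxymethyl on a saturated chain carbon bound to an oxygen on an aromatic ring), giving compound 4, `CC(C)=CCOc1cccc2ccc(N)nc12`. The measured step that bears most directly on it runs the other way, an at least 19-fold higher number from compound 2 to compound 3 (1.27 log units; beyond the scatter); the smaller at least 2.4-fold higher number from compound 1 to compound 3 (0.39 log units; beyond the scatter) points the same way. Both put the ethoxy-bearing chain of compound 3 at the highest number, while compound 4 carries a chain of carbon only, so a large fall in the number toward compound 2 is expected in this assay. The estimate for compound 4 is 250 nM, range 70 nM to 1000 nM, an expected step of an at least 8.0-fold lower number from compound 3 to compound 4 (0.90 log units; beyond the scatter).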

Compound 4, half-maximal inhibitory concentration: > 2000 nM
Compound 4 ended at the assay's limit; the forecaster's own chance of this, stated with the estimate: 10%; middle value at least 8.0-fold (0.90 log units) away from the limit.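

Compound 4 also rests at a limit of the assay, so a chain of carbon only on this oxygen does not by itself bring a measured value: the limit of > 2000 nM in this assay, at which 2 of the 4 values shown sit.

The change from 1-methylbutyl to 3-methylbut-2-en-1-yl is large, an at least 19-fold higher number from compound 2 to compound 4 (1.27 log units; beyond the scatter), so a high number here does not depend on an ether oxygen in the chain. The step between compound 3 and compound 4 cannot be read.

From the compounds shown here alone, whether the double bond or the shape of the chain carries that loss stays open. Going by these compounds, how an amine at the end of a longer chain would read here also stays open.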